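Carboxy for sulfamoyl in a series held at limits

The compounds below may be only part of what the source reports. "The series", "measured", "known", "first", "only" and "open" are said of these compounds alone.

Measured so far in an ADME assay on TZM cells (Homo sapiens) for cytotoxicity, read by XTT assay, with a stated time of 4 days; a higher number here means that more compound is tolerated, a lower number that less compound is tolerated:
- compound 1 `Cc1cc(/C=C/C#N)cc(C)c1Oc1cc(Nc2ccc(C#N)cc2)c(N)cc1S(N)(=O)=O`: > 21800 nM, a limit
- compound 2 `Cc1cc(CCC#N)cc(C)c1Oc1cc(Nc2ccc(C#N)cc2)c(N)cc1C(=O)NN`: > 22700 nM, a limit
- compound 3 `Cc1cc(CCC#N)cc(C)c1Oc1cc(Nc2ccc(C#N)cc2)c(N)cc1C(N)=O`: > 9400 nM, a limit

Compound 1 is known only as a limit, > 21800 nM, and so are the other two compounds, which leaves no number against which to place it. The next compound is compound 4 `Cc1cc(/C=C/C#N)cc(C)c1Oc1cc(Nc2ccc(C#N)cc2)c(N)cc1C(=O)O`, which keeps the rest of compound 1 and carries carboxy in place of sulfamoyl on an aromatic carbon.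

Among the measured compounds shown here, the one measured step is a step that the two limits leave unreadable from compound 2 to compound 3. It supplies no size to carry over, and it concerns a different group from the one changed here. The expectation therefore rests on compound 1, a limit at > 21800 nM, and on the absence of any numeric value among the measured compounds.

The expected step is a step that the limit leaves unreadable from compound 1 to compound 4, with no change beyond the scatter and no direction expected in this assay. Compound 4 may well be reported only as a limit too. The estimate for compound 4 is 23000 nM, with an expected range from 9000 nM to 45000 nM.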

Compound 4, half-maximal cytotoxic concentration: 14900 nM
Beside the measured number, compound 4's estimate is 1.5-fold (0.19 log units) above it, within the range that was stated.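

In this assay, compound 4 is the only one of the four compounds shown with a number rather than a limit: with carboxy on this aromatic carbon, ortho to a large group and para to a (4-cyanophenyl)amino group, compound 4 gives 14900 nM. Carboxy in place of sulfamoyl at this position therefore brings the series its first readable value, and the change is recorded as an at least 1.4-fold lower number from compound 1 to compound 4 (0.16 log units; that floor lies within the scatter), so the result does not establish a step beyond the scatter. The step remains a floor rather than a size because compound 1 is known only as a limit: the limit of > 21800 nM in this assay, at which 1 of the 4 values shown sits.

Going by these compounds, compound 4 cannot be set against compound 3, as the two differ both in the chain and in the group at this position, so the effect of carboxy against a carboxamide on the same chain remains open. Also open, on these data alone, is whether a methyl ester or a tetrazole on this aromatic carbon would give a number like compound 4 or stand as a limit like compound 1.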